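Removing the Cyclohexyl Group: Cytotoxicity in Hamster Cells

This account rests on a few compounds, and the source may have more. Where it says the series, first, only, none or still open, it means among the compounds named here.

Compound 1, `CCC(=O)Nc1ccc(-c2nc3cc(C(F)(F)F)ccc3n2C2CCCCC2)cc1`: 15000 nM
Compound 2, `CCC(=O)Nc1ccc(-c2nc3cc(C(F)(F)F)ccc3[nH]2)cc1`: 100000 nM
Compound 3, `CC(=O)Nc1ccc(-c2nc3cc(C(F)(F)F)ccc3n2C2CCCCC2)cc1`: 15000 nM

These three compounds were tested in an ADME assay on BHK cells (Mesocricetus auratus) for cytotoxicity, read by MTT assay, with a stated time of 96 h; a higher number here means that more compound is tolerated, a lower number that less compound is tolerated. Compound 1 and compound 2 differ in one place: hydrogen in place of cyclohexyl on an aromatic nitrogen. That single change produced a 6.7-fold higher number from compound 1 to compound 2 (0.82 log units; beyond the scatter). Compound 1 and compound 3 differ in their cores only by hydrogen in place of methyl on a saturated chain carbon bound to a carbonyl carbon, a change that gave no change at the digits printed from compound 1 to compound 3 (within the scatter).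

Compound 4, `CC(=O)Nc1ccc(-c2nc3cc(C(F)(F)F)ccc3[nH]2)cc1`, has not yet been measured. It differs from compound 3 in that (hydrogen in place of cyclohexyl on an aromatic nitrogen). Among the measured compounds shown here, this is the same change as the one between compound 1 and compound 2, at the same place, so that earlier step is the only guide available. Since compound 3 stands at 15000 nM, and the earlier step was a 6.7-fold higher number from compound 1 to compound 2 (0.82 log units; beyond the scatter), compound 4 is expected to move by about a 6.7-fold higher number from compound 3 to compound 4 (0.82 log units; beyond the scatter). The estimate for compound 4 in this assay is therefore 100000 nM, expected to lie between 40000 nM and 200000 nM. This rests on a single earlier step and remains uncertain until measured.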

Compound 4, half-maximal cytotoxic concentration: 53000 nM
Compound 4: the middle estimate sits 1.9-fold (0.28 log units) above what was measured, and the stated range covers the measured number.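

In this assay, putting hydrogen in place of cyclohexyl on the aromatic nitrogen of compound 3 gave a 3.5-fold higher number from compound 3 to compound 4 (0.55 log units; beyond the scatter), so the move seen on the first core recurs on the second, and the two steps agree as closely as repeated measurements can show: the same change on two cores in this assay, a 6.7-fold higher number (0.82 log units; beyond the scatter) from compound 1 to compound 2 and a 3.5-fold higher number (0.55 log units; beyond the scatter) from compound 3 to compound 4, 1.9-fold (0.28 log units) apart, within the scatter of two such steps. The other change, hydrogen in place of methyl on the saturated chain carbon bound to the carbonyl carbon, gave a 1.9-fold lower number from compound 2 to compound 4 (0.28 log units; within the scatter), and it too carries over from one core to the other: the same change on two cores in this assay, no change at the digits printed (within the scatter) from compound 1 to compound 3 and a 1.9-fold lower number (0.28 log units; within the scatter) from compound 2 to compound 4, 1.9-fold (0.28 log units) apart, within the scatter of two such steps. Among the compounds shown here, this rests on only two pairs of compounds in a single cell assay, so it does not show that either step would hold on other cores, and it does not explain why the number moves.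

The compounds shown leave open what a methyl group or a phenyl ring on that aromatic nitrogen would give in place of cyclohexyl. They also leave open how a longer chain or an amine on the carbonyl carbon would behave.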